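A few compounds are considered here, and "the series" means these few. Any claim that something is new, unique, unknown or untested is made for them only; others in the source may bear on it.

Compound 1 `Cc1ccc(/N=N/N(C)C(=O)NCCSc2ccc(O)cc2)cc1` and compound 3 `CCOC(=O)c1ccc(/N=N/N(C)C(=O)NCCSc2ccc(O)cc2)cc1` are built on one shared core and differ at a single place on an aromatic ring. Among the compounds with values here, in a physicochemical assay for lipophilicity, read by HPLC, in phosphate buffer, measured as octanol-water partition, with a stated time of 30 min (a higher number here means a more lipophilic compound, a lower number a more polar compound), compound 1 gives 4.21, and this is the only number in the set. Compound 2 `CN(/N=N/c1ccc(Br)cc1)C(=O)CCc1ccc(O)cc1`, which has a different core, was entered in this assay as "not determined" (no result reported), so no number came back for it. On the values shown, compound 1 therefore stands alone, with nothing to rank it against. The change from compound 1 to compound 3 is ethoxycarbonyl in place of methyl on an aromatic carbon. Within the data shown here, no pair of measured compounds differing in one place is available, so the size of this step cannot be read from a neighbour. The expectation is that a number 0.06 log units lower from compound 1 to compound 3 (within the scatter) amounts to no step beyond the usual scatter. Compound 3 is accordingly estimated at 4.15 in this assay, within a range from 3.65 to 4.65.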

Compound 3, partition coefficient: 4.08
For compound 3 the middle estimate is 0.07 log units above the measured one; the range from low to high includes it.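

In this assay, within the data shown here, putting ethoxycarbonyl in place of methyl on an aromatic carbon, para to a large group, gives the first measured step at this position: a number 0.13 log units lower from compound 1 to compound 3 (within the scatter). The entering group has 5 heavy atoms and 2 hydrogen-bond acceptors, whereas methyl has 1 heavy atom and no acceptors, yet this sizeable change in structure does not separate the two compounds beyond the scatter. Nothing measured here explains why the two readings stay so close.

Going by these compounds, it remains open whether another group at this place, such as an amine, a carboxylic acid or a longer alkyl chain, would shift the reading beyond the scatter. On these data alone, compound 2 has a different core and no number, so whether this swap behaves alike on another core also remains open.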